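The source may hold more compounds than are shown below. What is called first, only, known or untested is meant among the compounds shown, and "the series" means these compounds.

In a functional assay on A2780 cells (Homo sapiens) for inhibition, read by MTT assay, with a stated time of 72 h (a higher number here means a weaker inhibitor of growth, a lower number a stronger inhibitor of growth), three compounds have been measured so far:
compound 1 `N#C/C(=C\c1c[nH]c2ccccc12)C(=O)c1c[nH]c2ccccc12` gives 9300 nM;
compound 2 `N#C/C(=C\c1ccc[nH]1)C(=O)NCc1ccc(Cl)c(Cl)c1` gives > 50000 nM, which is a limit of the assay rather than a number;
compound 3 `COc1ccc(CNC(=O)/C(C#N)=C/c2ccco2)cc1` gives 24000 nM.

Compound 2 thus sits at the limit of > 50000 nM in this assay, at which 1 of the 3 values shown sits, so its growth inhibition is known only as a limit, not as a value. Compound 4 `N#C/C(=C\c1ccco1)C(=O)NCc1ccc(Cl)c(Cl)c1` differs from compound 2 by furan-2-yl in place of 1H-pyrrol-2-yl on a double-bonded chain carbon bound to a double-bonded chain carbon. Among the compounds with values here, no pair of measured compounds traces this exchange on its own. Compound 3 carries the same furan-2-yl group with a different amide portion and gives 24000 nM, which offers the only hint of where a furan-bearing compound lands. The expected step is an at least 1.2-fold lower number from compound 2 to compound 4 (0.09 log units; that floor lies within the scatter), modest and hardly beyond the usual scatter. Compound 4 is therefore estimated at 40000 nM. Its range is expected to run from 15000 nM to 100000 nM.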

Compound 4, concentration for 50% growth inhibition: > 50000 nM
Compound 4 was reported as a limit; the forecaster's own chance of this, stated with the estimate: 45%; middle value at least 1.2-fold (0.09 log units) from the limit.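

Within the data shown here, compound 2 and compound 4 are both reported only as limits, so no step between them can be read: the limit of > 50000 nM in this assay, at which 2 of the 4 values shown sit. As far as these compounds go, whether furan-2-yl or 1H-pyrrol-2-yl gives the stronger growth inhibition on this amide stays open.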